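From carboxy to 1,3-oxazol-2-yl on the chain carbon

The compounds below may be only part of what the source reports. "The series", "measured", "known", "first", "only" and "open" are said of these compounds alone.

The three measured compounds share one core, seen first in compound 1 `CCOC(=O)CN(c1ccccc1)C1c2cc(C#N)ccc2OC(C)(C)C1O`. In a functional assay (aorta) with Rattus norvegicus as the target (a higher number here means a weaker inhibitor, a lower number a stronger inhibitor), compound 1 reaches only a limit, > 30000 nM, as the limit of > 30000 nM in this assay, at which 1 of the 3 values shown sits, records. Compound 2 `CC1(C)Oc2ccc(C#N)cc2[C@H](N(CC(=O)O)c2ccccc2)[C@H]1O` carries a carboxy group on a saturated chain carbon bound to a nitrogen on an aromatic ring. In this assay compound 2 likewise gives only a limit, > 100000 nM. Compound 2 therefore stands at the weak end of the numbers shown, without a number of its own, the limit being (the limit of > 100000 nM in this assay, at which 1 of the 3 values shown sits). Compound 3 `CC1(C)Oc2ccc(C#N)cc2[C@H](N(Cc2ccco2)c2ccccc2)[C@H]1O` has furan-2-yl on that chain carbon, and in this assay compound 3 gives 12000 nM. Going by the values given here, the single measured step that bears on the question is an at least 8.3-fold lower number from compound 2 to compound 3 (0.92 log units; beyond the scatter), a clear drop in the read-out when a five-membered aromatic ring stands in place of the acid.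

Compound 4 `CC1(C)Oc2ccc(C#N)cc2[C@H](N(Cc2ncco2)c2ccccc2)[C@H]1O` differs from compound 2 as follows: 1,3-oxazol-2-yl in place of carboxy on a saturated chain carbon bound to a nitrogen on an aromatic ring. Since 1,3-oxazol-2-yl is again a five-membered aromatic ring replacing carboxy, a step of comparable size in the same direction is expected: an at least 6.6-fold lower number from compound 2 to compound 4 (0.82 log units; beyond the scatter). The estimate for compound 4 in this assay is 15000 nM, expected to fall between 4000 nM and 60000 nM.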

Compound 4, half-maximal inhibitory concentration: > 30000 nM
Compound 4 was reported as a limit; the forecaster's own chance of this, stated with the estimate: 20%; at least 2.0-fold (0.30 log units) between middle value and limit.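

In this assay, the two five-membered aromatic rings do not behave alike on a saturated chain carbon bound to a nitrogen on an aromatic ring: replacing furan-2-yl with 1,3-oxazol-2-yl gives an at least 2.5-fold higher number from compound 3 to compound 4 (0.39 log units; beyond the scatter). The lower number seen when furan-2-yl replaces carboxy therefore does not extend to every five-membered aromatic ring at this place, and in this pair the ring that enters with a ring nitrogen is the one that gives no measured number. Compound 4 records only a limit, and with compound 2 also at a limit, the step between them cannot be read: the limit of > 30000 nM in this assay, at which 2 of the 4 values shown sit.

As far as these compounds go, how far the true value of compound 4 lies from its limit stays open, so the gap between the two rings is known only as a minimum. Also open, from the compounds shown here alone, is whether a 1,3-thiazol-2-yl or a plain phenyl on the same chain carbon would fall with furan-2-yl or with 1,3-oxazol-2-yl, since one pair of rings cannot show which atoms of the ring govern the read-out.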